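The compounds below may be only part of what the source reports. "The series", "measured", "known", "first", "only" and "open" are said of these compounds alone.

The series shares one core, seen in compound 1 `Cn1cnc(S(=O)(=O)N(CC(=O)OC(C)(C)C)C2Cc3cc(C#N)ccc3N(Cc3cncn3C)C2)c1` and compound 2 `Cn1cnc(S(=O)(=O)N(Cc2ccc(-n3cccn3)cc2)C2Cc3cc(C#N)ccc3N(Cc3cncn3C)C2=O)c1`, each measured in an in vitro ADME assay on microsomes from liver (Mus musculus) for metabolic stability; a lower number here means that the compound disappears faster, a higher number that the compound lasts longer. In this assay compound 1 gives 10 h. For the measured compounds named here, compound 2 gives 9 h in this assay, which is one of only two numbers so far, and its value and that of compound 1 lie within the usual scatter of each other, so the two compounds cannot be told apart on half-life. Compound 3 `Cn1cnc(S(=O)(=O)N(Cc2ccc(C#N)cc2)C2Cc3cc(C#N)ccc3N(Cc3cncn3C)C2=O)c1` is not yet measured. It differs from compound 2 by cyano in place of 1H-pyrazol-1-yl on an aromatic carbon. Going by the values given here, no step between two measured compounds is available to guide the expectation, so nothing beyond the scatter is anticipated in either direction. The half-life of compound 3 is therefore estimated at 9 h, with a range from 4.5 h to 18 h, an expected step of no change at the digits printed from compound 2 to compound 3 (within the scatter).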

Compound 3, half-life: 40 h
Compound 3: the middle estimate sits 4.4-fold (0.65 log units) below what was measured; the measured number lies above the stated range.
By their numbers in this assay, from the lowest: compounds 2 and 1 (each within the scatter of the next); then compound 3.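

For the compounds shown here, the first comparison that differs in one place shows that this position matters: with cyano in place of 1H-pyrazol-1-yl on an aromatic carbon, para to a large group, this assay gives a 4.4-fold higher number from compound 2 to compound 3 (0.65 log units; beyond the scatter) for the change from 4-(1H-pyrazol-1-yl)benzyl to 4-cyanobenzyl. Compounds 1 and 2 could not show this, as they differ in more than one place and their half-lives lie within the scatter of each other. Nothing available here accounts for the change in half-life.

Going by these compounds, whether the longer half-life is specific to cyano remains open, as does how a methoxy group, a chlorine atom or a carboxylic acid would fare at this place. On these data alone, it is also open whether the same change would have a similar effect on the core of compound 1.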